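This account rests on a few compounds, and the source may have more. Where it says the series, first, only, none or still open, it means among the compounds named here.

Measured compounds in a physicochemical assay for lipophilicity, read by HPLC, at pH 7.5; on this read-out lower numbers stand for lower lipophilicity and higher numbers for higher lipophilicity:
- compound 1, `CCOc1ccccc1-c1ccc(-c2nc3cnccc3cc2C#N)cc1`, 3.8
- compound 2, `CCOc1ccccc1-c1ccc(-c2nc3cncc(Cl)c3c(N[C@H](CC)C(N)=O)c2C#N)cc1`, 3.7
- compound 3, `CC[C@@H](Nc1c(C#N)c(-c2ccc(-c3cnccc3C)cc2)nc2cnccc12)C(N)=O`, 2

Compound 3 stands lowest of the three numbers. Its nearest neighbour is compound 2, whose value is well beyond the scatter above it, and compound 1 lies further still; both gaps are clearly outside the usual scatter, so compound 3 is the least lipophilic of the measured set in this assay. No two of these compounds differ in a single place, so no single-point step is available to lean on.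

Compound 4, `CC[C@@H](Nc1c(C#N)c(-c2ccc(-c3cccc(OC)c3)cc2)nc2cnccc12)C(N)=O`, is the next entry and has not yet been measured. It differs from compound 3 as follows: 3-methoxyphenyl in place of 4-methylpyridin-3-yl on an aromatic carbon

Going by the values given here, since no measured pair isolates this change, the expectation rests on the spread of the three numbers. Compound 1 and compound 2, which both carry carbon-only outer rings, give the two higher values, while compound 3 with its 4-methylpyridin-3-yl group gives the low value. Compound 4 is therefore expected to move upward in this assay by a step of about a number 1.00 log units higher from compound 3 to compound 4 (beyond the scatter), beyond the scatter, landing below compound 1 and compound 2. The estimate for compound 4 is 3, within a range of 2.5 to 3.5.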

Compound 4, distribution coefficient: 2.7
Compound 4: middle estimate off by 0.30 log units, on the high side; measured number inside the range.
By their numbers in this assay, from the lowest: compound 3; then compound 4; then compounds 2 and 1 (each within the scatter of the next).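

In this assay, going by these compounds alone, 3-methoxyphenyl in place of 4-methylpyridin-3-yl, on an aromatic carbon para to a large group, gives a number 0.70 log units higher from compound 3 to compound 4 (beyond the scatter) as the first step that isolates a single place. The read-out therefore responds to the identity of the group at this position, even with the rest of the structure held constant. The two groups match in hydrogen-bond donors, hydrogen-bond acceptors and net charge, so those counts do not separate them, and no measurement shown accounts for the step.

The change swaps the ring nitrogen for carbon and the methyl for a methoxy group at the same time, so the shares of these two differences in the step remain unresolved. A plain phenyl ring, a methoxypyridine ring or a ring carrying an amine or a carboxylic acid at this position would show whether the read-out follows the ring atoms, the substituent or both.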